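Urea versus amide in pyrazole anticancer agents on OVCAR-8 cells

A few compounds are considered here, and "the series" means these few. Any claim that something is new, unique, unknown or untested is made for them only; others in the source may bear on it.

Measured so far:
compound 1, `COc1cc(Cl)cc(-c2nn(-c3cccc(NC(=O)c4ccc(Cl)c(Cl)c4)c3)cc2-c2ccncc2)c1`, 58.4%
compound 2, `O=C(Nc1cccc(-n2cc(-c3ccncc3)c(-c3cc(O)cc(Cl)c3)n2)c1)Nc1ccc(Cl)c(Cl)c1`, -14.8%
compound 3, `COc1cc(Cl)cc(-c2nn(-c3cccc(NC(=O)Nc4ccc(Cl)c(C(F)(F)F)c4)c3)cc2-c2ccncc2)c1`, 8.71%

All three numbers come from a functional assay on OVCAR-8 cells (Homo sapiens) for inhibition, read by sulforhodamine B assay, with a stated time of 48 h, tested at 10 uM; a lower number here means a stronger effect, a higher number a weaker effect of the compound at the concentration tested. Compound 3 stands second highest of the three: compound 2 lies beyond the scatter below it, and compound 1 lies beyond the scatter above it. Among the measured compounds shown here, the one step between compounds that differ in a single place is a number 49.7 percentage points lower from compound 1 to compound 3 (beyond the scatter), a large fall that pairs an exchange of the amide for a urea with a change on the outer ring.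

Compound 4, `COc1cc(Cl)cc(-c2nn(-c3cccc(NC(=O)Nc4ccc(Cl)c(Cl)c4)c3)cc2-c2ccncc2)c1`, is not yet measured in this assay. It differs from compound 3 by chloro in place of trifluoromethyl on an aromatic carbon. For the measured compounds named here, no measured step isolates this exchange. Compound 2 carries the same (3,4-dichlorophenyl)amino urea as compound 4 but with a hydroxy in place of the methoxy, and in this assay compound 2 gives -14.8%; compound 3 and compound 2 are therefore both far below compound 1. The expected step is a number 5.7 percentage points lower from compound 3 to compound 4 (within the scatter), small and within the scatter. For compound 4 in this assay the estimate is 3%, expected to lie between -20% and 28%.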

Compound 4, a percentage reported as activity, at one concentration (the size of the read-out at that concentration, not a potency): 1.93%
Estimate against measurement, compound 4: 1.1 percentage points above; low and high end bracket the measured number.
By their numbers in this assay, from the lowest: compound 2; then compounds 4 and 3 (each within the scatter of the next); then compound 1.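

In this assay the exchange of trifluoromethyl for chloro, on an aromatic carbon ortho to a chloro group, now stands alone, and the step is a number 6.8 percentage points lower from compound 3 to compound 4 (within the scatter) so the data do not separate the two groups at this position within the urea series. Compound 4 also removes the ambiguity left by the earlier comparison of compound 1 with compound 3: with the 3,4-dichlorophenyl group held constant, placing (3,4-dichlorophenyl)amino on the carbonyl carbon gives a number 56.5 percentage points lower from compound 1 to compound 4 (beyond the scatter) and so the urea in place of the amide accompanies a large fall without any change on the outer ring. On the other aromatic ring, methyl in place of hydrogen on the oxygen gives a number 16.7 percentage points higher from compound 2 to compound 4 (beyond the scatter) which shows that this site also moves the read-out, though less than the amide-to-urea exchange does.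

The compounds shown leave open whether a urea would keep this level with an amine or a carboxylic acid at the place now held by chloro or trifluoromethyl, and whether the difference between hydroxy and methoxy would carry over to the trifluoromethyl urea or to the amide. Nothing available here accounts for the size of any of these steps.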